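Cyclohexyl for sec-butyl on the amine of a curcumin-like chain

The source may report more compounds than this note shows. Statements on the series, on what has been measured and on what is new or still open speak of the compounds shown alone.

Of the compounds shown here, two have been measured in a functional assay on Caco-2 cells (Homo sapiens), read by fluorescence, tested at 1 uM; on this read-out higher numbers stand for a weaker effect at the one concentration tested and lower numbers for a stronger effect. Compound 1 `COc1cc(/C=C/C(=O)/C=C(/C=C/c2ccc(OC(C)=O)c(OC)c2)NC2CCCCC2)ccc1OC(C)=O` gives 89%. Compound 2 `CCC(C)NC(=C\C(=O)/C=C/c1ccc(O)c(OC)c1)/C=C/c1ccc(O)c(OC)c1` gives 91%. The number of compound 2 and that of compound 1 differ by an amount within the scatter, so neither can be set apart from the other. Compound 3 `COc1cc(/C=C/C(=O)/C=C(/C=C/c2ccc(O)c(OC)c2)NC2CCCCC2)ccc1O` has not been measured; it differs from compound 2 in one place, (cyclohexyl in place of sec-butyl on an amine nitrogen). For the measured compounds named here, no measured pair shows this change, so the step from compound 2 to compound 3 is expected to stay within the scatter, a number 1 percentage points lower from compound 2 to compound 3 (within the scatter). Compound 3 is estimated at 90%, between 80% and 98%.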

Compound 3, a percentage reported as activity, at one concentration (the size of the read-out at that concentration, not a potency): 88%
Compound 3: the middle estimate sits 2 percentage points above what was measured; low and high end bracket the measured number.
By their numbers in this assay, from the lowest: compounds 3, 1 and 2 (each within the scatter of the next).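

In this assay, for the compounds shown here, cyclohexyl in place of sec-butyl on the amine nitrogen gives a number 3 percentage points lower from compound 2 to compound 3 (within the scatter) and this is the first direct reading of that change. So at this position, a six-membered carbon ring and an open branched group cannot be told apart at the one concentration tested. Nothing available here offers an explanation for this result.

As far as these compounds go, what remains open is whether a different group on this nitrogen, such as a phenyl ring or a longer chain, would move the number beyond the scatter.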